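Oxime oxygen substitution on the shared core

The compounds below may be only part of what the source reports. "The series", "measured", "known", "first", "only" and "open" are said of these compounds alone.

compound 1 `CCOC(=O)/C(=N\O)c1ccc(Sc2cc(F)cc(C3CCOCC3)c2)cc1`: 170 nM
compound 2 `CO[C@]1(c2cc(F)cc(Sc3ccc(/C(C)=N/OCC#N)cc3)c2)CCO[C@@H](C)C1`: 40 nM

Among the measured compounds shown here, in a functional assay (blood) for inhibition, with Homo sapiens as the target (a lower number here means a stronger inhibitor, a higher number a weaker inhibitor), compound 1 gives 170 nM, the higher of the two numbers so far; compound 2 gives 40 nM, a gap beyond the scatter, but the two differ in several places and no single step joins them. Compound 3 `CC(=O)O/N=C(\C)c1ccc(Sc2cc(F)cc(C3CCOCC3)c2)cc1` is not yet measured. It keeps the core of compound 1 and differs in one place: a group of 7 heavy atoms (4 carbon, 1 nitrogen, 2 oxygen; no ring) in place of a group of 8 heavy atoms (4 carbon, 1 nitrogen, 3 oxygen; no ring), on an aromatic carbon. The leaving group holds the only hydrogen-bond donor; the entering group has none. Compound 2, whose oxime oxygen is likewise substituted, gives 40 nM, which supports a tolerated or mildly favourable change, though its core is different. The step from compound 1 to compound 3 is expected to be small, downward if anything, a 1.4-fold lower number from compound 1 to compound 3 (0.15 log units; within the scatter). Compound 3 is expected at 120 nM, with a range of 40 nM to 350 nM.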

Compound 3, half-maximal inhibitory concentration: 50 nM
Beside the measured number, compound 3's estimate is 2.4-fold (0.38 log units) above it; low and high end bracket the measured number.
By their numbers in this assay, from the lowest: compounds 2 and 3 (each within the scatter of the next); then compound 1.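

In this assay, among the compounds shown here, the change on an aromatic carbon para to a large group gives a 3.4-fold lower number from compound 1 to compound 3 (0.53 log units; beyond the scatter) and provides the first reading at this position from a change in one place. The hydrogen-bond donor of the leaving group is not needed to reach the lower number in this pair: the entering group has none, and the step lies beyond the scatter. No measured property on hand accounts for the size or direction of this step.

The whole group is replaced at once, and the compounds shown do not separate the loss of the oxime hydroxyl from the other differences within that group. From the compounds shown here alone, whether a carboxylic acid, an amide or a longer chain on the oxime oxygen would keep the lower number at this place remains open.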